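From 2-Fluorophenyl to 3-Bromopropyl: One Untested Step

The source may hold more compounds than are shown below. What is called first, only, known or untested is meant among the compounds shown, and "the series" means these compounds.

Measured so far:
compound 1 `Cc1ccc(S(=O)(=O)Nc2ccc3c(c2)C(=O)N(CCOc2ccc(O)cc2)C3=O)cc1` — 100000 nM
compound 2 `Cc1ccc(S(=O)(=O)Nc2ccc3c(c2)C(=O)N(Cc2ccccc2F)C3=O)cc1` — 180000 nM

Of the compounds shown here, two have been measured in an assay on isolated protein for inhibition of lactase/phlorizin hydrolase (Rattus norvegicus), read by colorimetric assay; a higher number here means a weaker inhibitor, a lower number a stronger inhibitor. Compound 1 gives 100000 nM and compound 2 gives 180000 nM. For the measured compounds named here, the single step between them, a 1.8-fold higher number from compound 1 to compound 2 (0.26 log units; within the scatter), lies within the scatter, so the two numbers cannot be ordered. Going by the values given here, compound 2 holds the higher of the two numbers, with compound 1 as its only neighbour at a distance inside the scatter; both are weak inhibitors on this evidence.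

Compound 3 `Cc1ccc(S(=O)(=O)Nc2ccc3c(c2)C(=O)N(CCCCBr)C3=O)cc1` has not yet been measured. It differs from compound 2 in one place: 3-bromopropyl in place of 2-fluorophenyl on a saturated chain carbon bound to an amide-type nitrogen in a ring. Among the compounds with values here, only one measured step exists, and it concerns the same place on the shared core but exchanges one group for another of a different kind; it is within the scatter and gives no direction for the entry of a chain. With nothing that bears on this change, the expected step, a 1.2-fold lower number from compound 2 to compound 3 (0.08 log units; within the scatter), is none beyond the scatter. Compound 3 is therefore estimated at 150000 nM, within a range of 50000 nM to 500000 nM.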

Compound 3, half-maximal inhibitory concentration: > 200000 nM
Compound 3 was reported as a limit; the forecaster's own chance of this, stated with the estimate: 25%; at least 1.3-fold (0.12 log units) between middle value and limit.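

In this assay, compound 3 is reported as a limit and not as a number: the limit of > 200000 nM in this assay, at which 1 of the 3 values shown sits. Exchanging 2-fluorophenyl, with its six-membered aromatic ring, for 3-bromopropyl, with no ring, gives an at least 1.1-fold higher number from compound 2 to compound 3 (0.04 log units; that floor lies within the scatter), and exchanging 4-hydroxyphenoxy for 2-bromoethyl gives an at least 2.0-fold higher number from compound 1 to compound 3 (0.30 log units; that floor lies within the scatter). The earlier compounds shown here both carried an aromatic ring in this substituent, so the new information is that a chain with no ring, ending in bromine, gives no lower number than either of them in this assay, although neither floor separates compound 3 from the other two.

Going by these compounds, how far the true value of compound 3 lies past its limit remains open, and so does the true size of both steps, which leaves unsettled whether the ring in this substituent matters at all. On these data alone, it is also open whether any group at this place gives a clearly lower number, for example an amine or a carboxylic acid in place of the bromine, or a longer chain.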